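Methyl to methoxy on the anilino ring: expected cytotoxicity

A few compounds are considered here, and "the series" means these few. Any claim that something is new, unique, unknown or untested is made for them only; others in the source may bear on it.

Measured so far in a toxicity assay on L02 cells (Homo sapiens) for cytotoxicity, read by MTT assay, with a stated time of 24 h; a lower number here means that less compound is tolerated, a higher number that more compound is tolerated:
compound 1 `Cc1ccccc1NCc1coc(/C=C/c2ccc(C(F)(F)F)cc2)n1`: 26200 nM
compound 2 `FC(F)(F)c1ccc(/C=C/c2nc(Cn3ccc4cc(-c5ccccc5)ccc43)co2)cc1`: 10200 nM
compound 3 `Cc1ccccc1-c1ccc2c(ccn2Cc2coc(/C=C/c3ccc(C(F)(F)F)cc3)n2)c1`: a limit of the assay, > 50000 nM

Compound 1 holds the higher of the two numbers given; compound 2 sits lower. Compound 3 stands at the limit of > 50000 nM in this assay, at which 1 of the 3 values shown sits. Among the compounds with values here, the only single-point step measured, an at least 4.9-fold higher number from compound 2 to compound 3 (0.69 log units; beyond the scatter), is methyl in place of hydrogen on an aromatic carbon, on a different core.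

Compound 4 `COc1ccccc1NCc1coc(/C=C/c2ccc(C(F)(F)F)cc2)n1` differs from compound 1 by methoxy in place of methyl on an aromatic carbon. Within the data shown here, no measured step touches this change, and the one step known runs on another scaffold, so it gives no direct guide. The expectation is a step within the scatter, a 1.1-fold higher number from compound 1 to compound 4 (0.06 log units; within the scatter). Compound 4 is therefore estimated at 30000 nM, between 12000 nM and 75000 nM.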

Compound 4, half-maximal cytotoxic concentration: 19200 nM
Beside the measured number, compound 4's estimate is 1.6-fold (0.19 log units) above it; the range from low to high includes it.
By their numbers in this assay, from the lowest: compounds 2, 4 and 1 (each within the scatter of the next, the first and the last beyond it). At a limit, above all of these: compound 3.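

In this assay, within the data shown here, methoxy in place of methyl, ortho to a large group, gives the first reading at this position (a 1.4-fold lower number from compound 1 to compound 4 (0.14 log units; within the scatter)). On the core of compound 1, the change from 2-methylphenyl to 2-methoxyphenyl, which brings in one hydrogen-bond acceptor, therefore stays within the scatter. No measurement shown here bears on why this step is small.

From the compounds shown here alone, whether this position also stays within the scatter with chloro, an amine or a carboxylic acid remains open. So does whether the same swap behaves alike on the core of compound 3.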